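This account rests on a few compounds, and the source may have more. Where it says the series, first, only, none or still open, it means among the compounds named here.

Compounds measured in a functional assay on PC-3 cells (Homo sapiens) for inhibition, read by MTT assay, with a stated time of 24 h; a lower number here means a stronger inhibitor, a higher number a weaker inhibitor:
compound 1 `Cc1nc2ccccc2nc1OCC(=O)Nc1ccc(Cl)cc1`: 68100 nM
compound 2 `Cc1ccc(NC(=O)COc2nc3ccccc3nc2/C=C\c2ccncc2)cc1`: > 100000 nM, a limit of this assay and not a number (the limit of > 100000 nM in this assay, at which 1 of the 2 values shown sits).

Compound 2 thus stands at the limit, while compound 1 gives a measured, weak number. The change to compound 3 `O=C(COc1nc2ccccc2nc1/C=C\c1ccncc1)Nc1ccc(Cl)cc1` is chloro in place of methyl on an aromatic carbon. Among the measured compounds shown here, no measured step covers this change on its own; compound 1 carries the chloro group but differs from compound 2 in a second place as well, so its value cannot be read as a step. The expected step in this assay is a number no higher from compound 2 to compound 3 (the limit leaves the size open), none beyond the scatter. Compound 3 is estimated at 100000 nM, range 40000 nM to 250000 nM, with a fair chance that only a limit is returned again.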

Compound 3, half-maximal inhibitory concentration: > 100000 nM
Compound 3 ended at the assay's limit (the forecaster's own chance of this, stated with the estimate: 55%); the middle value sits exactly at the limit.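

In this assay compound 3 gives > 100000 nM, a limit of the assay and not a number. With the 4-chlorophenyl group held, 2-(pyridin-4-yl)ethenyl in place of methyl gives an at least 1.4-fold higher number from compound 1 to compound 3 (0.16 log units; that floor lies within the scatter), the first step readable in this series. The step for chloro in place of methyl cannot be read because both of its ends sit at the limit: the limit of > 100000 nM in this assay, at which 2 of the 3 values shown sit.

Open, from the compounds shown here alone, is how far compound 2 and compound 3 lie past the limit. Also open, going by these compounds, is whether an amine or a longer chain in place of the 2-(pyridin-4-yl)ethenyl group would return a measurable value.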